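The compounds below may be only part of what the source reports. "The series", "measured", "known", "first", "only" and "open" are said of these compounds alone.

Measured in a functional assay; a lower number here means a stronger inhibitor, a higher number a weaker inhibitor:
- compound 1 `CC(C)=CCOc1cc(O)c2c(c1)OC(c1ccccc1)CC2=O`: 7320 nM
- compound 2 `CC(C)=CCOc1cc(O)c2c(c1)OC(c1ccccc1Cl)CC2=O`: 4270 nM
- compound 3 `CC(C)=CCOc1cc(O)c2c(c1)OC(c1cccc(Cl)c1)CC2=O`: 6060 nM

Compound 3 stands close to the other two, with a 1.2-fold lower number from compound 1 to compound 3 (0.08 log units; within the scatter) and a 1.4-fold higher number from compound 2 to compound 3 (0.15 log units; within the scatter). Compound 4 `CC(C)=CCOc1cc(O)c2c(c1)OC(c1ccc(Cl)cc1Cl)CC2=O` has not yet been measured. It carries 2,4-dichlorophenyl in place of 3-chlorophenyl on a saturated ring carbon. Going by the values given here, the steps that bear on this change are the two replacements of hydrogen by chloro, a 1.7-fold lower number from compound 1 to compound 2 (0.23 log units; within the scatter) and a 1.2-fold lower number from compound 1 to compound 3 (0.08 log units; within the scatter). Among the compounds with values here, neither exceeds the scatter, and no measured compound carries the 2,4-dichlorophenyl group. No step beyond the scatter is therefore expected in this assay. The estimate is a 1.4-fold lower number from compound 3 to compound 4 (0.16 log units; within the scatter). Compound 4 is expected at 4200 nM, with an estimated range of 2000 nM to 8500 nM.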

Compound 4, half-maximal inhibitory concentration: 3340 nM
Estimate against measurement, compound 4: 1.3-fold (0.10 log units) above, and the stated range covers the measured number.
By their numbers in this assay, from the lowest: compounds 4, 2, 3 and 1 (each within the scatter of the next, the first and the last beyond it).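

In this assay, going by these compounds alone, the 2,4-dichlorophenyl group gives the first step at this position that lies beyond the scatter, though a modest one: a 2.2-fold lower number from compound 1 to compound 4 (0.34 log units; beyond the scatter). Against the two compounds with a single chloro it stays within the scatter, with a 1.8-fold lower number from compound 3 to compound 4 (0.26 log units; within the scatter) and a 1.3-fold lower number from compound 2 to compound 4 (0.11 log units; within the scatter). Chloro in place of hydrogen on an aromatic carbon gave closely matching steps on the two cores: the same change on two cores in this assay, a 1.2-fold lower number (0.08 log units; within the scatter) from compound 1 to compound 3 and a 1.3-fold lower number (0.11 log units; within the scatter) from compound 2 to compound 4, 1.1-fold (0.02 log units) apart, within the scatter of two such steps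

The compounds shown leave open whether a methoxy group or a carboxylic acid on this phenyl ring, rather than chloro, would move the number further.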